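A few compounds are considered here, and "the series" means these few. Any claim that something is new, unique, unknown or untested is made for them only; others in the source may bear on it.

Measured compounds:
- Compound 1, `FC(F)(F)c1ccc(COc2cccc(Nc3ncnc4cc5c(cc34)OCCOCCOCCO5)c2)cc1`: 17600 nM
- Compound 2, `c1ccc(COc2ccc(Nc3ncnc4cc5c(cc34)OCCOCCOCCOCCO5)cc2)cc1`: 12000 nM
- Compound 3, `c1ccc(COc2cccc(Nc3ncnc4cc5c(cc34)OCCOCCOCCO5)c2)cc1`: > 100000 nM, which is a limit of the assay, not a number

In a functional assay on MCF7 cells (Homo sapiens) for antiproliferative activity, read by MTT assay, with a stated time of 72 h (on this read-out higher numbers stand for weaker inhibition and lower numbers for stronger inhibition), compound 1 gives 17600 nM and compound 2 gives 12000 nM. Compound 3 reaches only the limit of this assay at > 100000 nM, so for it just a boundary is known. Going by the values given here, the one measured step that touches compound 3 is an at least 5.6-fold higher number from compound 1 to compound 3 (0.75 log units; beyond the scatter): removing the trifluoromethyl left a compound weaker by at least that margin. Compound 3 itself sits at the limit of > 100000 nM in this assay, at which 1 of the 3 values shown sits.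

Compound 4, `O=[N+]([O-])c1ccc(COc2cccc(Nc3ncnc4cc5c(cc34)OCCOCCOCCO5)c2)cc1`, puts a group back at the same position: nitro in place of hydrogen on an aromatic carbon. Among the compounds with values here, no step with a nitro group has been measured, so the only guide is the trifluoromethyl-to-hydrogen step read backwards, where adding a substituent at this position lowered the number at least modestly. By that guide compound 4 is expected to give a lower number than compound 3, an at least 3.3-fold lower number from compound 3 to compound 4 (0.52 log units; beyond the scatter). The size of this expected step is uncertain, as compound 3 is known only as a limit. The estimate for compound 4 is 30000 nM, between 8000 nM and 150000 nM.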

Compound 4, half-maximal inhibitory concentration: > 100000 nM
Compound 4 ended at the assay's limit; the forecaster's own chance of this, stated with the estimate: 35%; middle value at least 3.3-fold (0.52 log units) from the limit.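

In this assay compound 4 gives > 100000 nM, which is a limit of the assay and not a number, so the step from compound 3 to compound 4 cannot be read. What can be read is that the gain seen with trifluoromethyl does not come with just any group at this position, since nitro in place of trifluoromethyl gives an at least 5.6-fold higher number from compound 1 to compound 4 (0.75 log units; beyond the scatter). Among these compounds, the position therefore responds to which group sits there, not merely to whether one does, and the weak end of the series is now a shared boundary: the limit of > 100000 nM in this assay, at which 2 of the 4 values shown sit.

As far as these compounds go, how far compound 3 and compound 4 really lie beyond that limit stays unknown, so hydrogen and nitro cannot be ranked against each other. From the compounds shown here alone, whether an amine, a carboxylic acid, a methoxy group or a chlorine atom at this position would side with trifluoromethyl or with nitro also stays open.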